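Swapping ethyl for pyridin-2-yl on the amino nitrogen

The source may report more compounds than this note shows. Statements on the series, on what has been measured and on what is new or still open speak of the compounds shown alone.

- Compound 1 `N#Cc1c(Cl)nc(SCc2nc3ccccc3[nH]2)nc1-c1ccccc1`: 8.62 nM
- Compound 2 `CNc1nc(SCc2nc3ccccc3[nH]2)nc(-c2ccccc2)c1C#N`: 3.28 nM
- Compound 3 `CCNc1nc(SCc2nc3ccccc3[nH]2)nc(-c2ccccc2)c1C#N`: 3.96 nM

These numbers come from a functional assay on GOTO cells (Homo sapiens) for cytotoxicity, read by MTT assay, with a stated time of 3 days; a higher number here means a weaker inhibitor, a lower number a stronger inhibitor. Compound 3 has no real gap to its nearest neighbour: a 1.2-fold higher number from compound 2 to compound 3 (0.08 log units; within the scatter). Its gap to the furthest number is larger: a 2.2-fold lower number from compound 1 to compound 3 (0.34 log units; beyond the scatter).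

Compound 4 `N#Cc1c(Nc2ccccn2)nc(SCc2nc3ccccc3[nH]2)nc1-c1ccccc1` keeps the shared core and changes one group: pyridin-2-yl in place of ethyl on a nitrogen on an aromatic ring. Ethylamino thus becomes (pyridin-2-yl)amino.

Replacing chloro with a small amino group gave modest steps: a 2.6-fold lower number from compound 1 to compound 2 (0.42 log units; beyond the scatter) and a 2.2-fold lower number from compound 1 to compound 3 (0.34 log units; beyond the scatter). The closest guide is the change on the nitrogen substituent itself, where a 1.2-fold higher number from compound 2 to compound 3 (0.08 log units; within the scatter). For the measured compounds named here, no measured compound carries a ring on that nitrogen, so this guide is weak and the range must stay wide.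

No shift beyond the scatter is expected, and the estimate reads a 1.0-fold higher number from compound 3 to compound 4 (0.00 log units; within the scatter). For compound 4 the expected value is 4 nM, with an estimated range from 1.5 nM to 12 nM.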

Compound 4, half-maximal inhibitory concentration: 2.5 nM
Beside the measured number, compound 4's estimate is 1.6-fold (0.20 log units) above it; measured number inside the range.
By their numbers in this assay, from the lowest: compounds 4, 2 and 3 (each within the scatter of the next); then compound 1.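

In this assay, the amino nitrogen accepts an aromatic ring as well as a small alkyl group: putting pyridin-2-yl in place of ethyl gives a 1.6-fold lower number from compound 3 to compound 4 (0.20 log units; within the scatter), and putting it in place of methyl gives a 1.3-fold lower number from compound 2 to compound 4 (0.12 log units; within the scatter). Set against chloro on the aromatic carbon, the (pyridin-2-yl)amino group gives a 3.4-fold lower number from compound 1 to compound 4 (0.54 log units; beyond the scatter), so the modest step seen with methylamino and ethylamino also holds for this much larger group. Nothing available explains why methyl, ethyl and pyridin-2-yl on this nitrogen sit within the scatter of one another.

Phenyl on the same nitrogen would test whether the ring nitrogen of pyridin-2-yl matters or the ring alone is enough. A longer chain such as butyl would show whether a larger group without a ring behaves the same way.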